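Halogen exchange on the aryl ring of compound 2

The source may report more compounds than this note shows. Statements on the series, on what has been measured and on what is new or still open speak of the compounds shown alone.

Two compounds have been run in a functional assay on NCI-H292 cells (Homo sapiens) for antiproliferative activity; on this read-out higher numbers stand for weaker inhibition and lower numbers for stronger inhibition. Compound 1 `COc1cccc(N2C(=O)N/C(=C\c3ccc(O)cc3)C2=O)c1` gives > 200000 nM, which is a limit of the assay and not a number, one of the two values resting at the limit of > 200000 nM in this assay, at which 1 of the 2 values shown sits. Among the compounds with values here, compound 2 `O=C1/C(=C/c2ccc(O)cc2)NC(=S)N1c1ccc(Cl)cc1` gives 28500 nM, the only full number so far. Compound 3 `O=C1/C(=C/c2ccc(O)cc2)NC(=S)N1c1ccc(I)cc1` carries iodo in place of chloro on an aromatic carbon, iodo in place of chloro on an aromatic carbon. Within the data shown here, no step of this kind has been measured. The change is expected to stay within the scatter, a 1.3-fold lower number from compound 2 to compound 3 (0.11 log units; within the scatter), in no set direction. Compound 3 is estimated at 22000 nM, in a range from 7000 nM to 70000 nM.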

Compound 3, half-maximal inhibitory concentration: 19700 nM
Compound 3: the middle estimate sits 1.1-fold (0.05 log units) above what was measured, and the stated range covers the measured number.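

In this assay, within the data shown here, 4-chlorophenyl to 4-iodophenyl gives a 1.4-fold lower number from compound 2 to compound 3 (0.16 log units; within the scatter), the first measured step at this position. Within this pair, the aromatic carbon accepts iodo in place of chloro without a change beyond the scatter, so the two halogens cannot be told apart on this read-out. No measured property available here bears on this step.

Going by these compounds, whether an amine or a carboxylic acid on the same carbon would leave the number unchanged stays open. So does the effect of fluoro or a methyl group there.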